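The source may report more compounds than this note shows. Statements on the series, on what has been measured and on what is new or still open speak of the compounds shown alone.

Series notes. The shared core is held constant while the aryl partner of the urea-free description varies; three members are measured, one is not.

Compound 1 `Cc1cc(NC(=O)Nc2ccc([N+](=O)[O-])c(C(F)(F)F)c2)c2ccccc2n1` in an ADME assay on HepG2 cells (Homo sapiens) for cytotoxicity, with a stated time of 72 h (a lower number here means that less compound is needed, a higher number that more compound is needed for the effect), gives > 25000 nM, which is a limit of the assay and not a number. Compound 2 `Cc1cc(NC(=O)Nc2ccc(C(=O)O)cc2)c2ccccc2n1` in this assay gives > 25000 nM, again a limit. Compound 3 `Cc1cc(NC(=O)Nc2cc(F)ccc2F)c2ccccc2n1` in this assay gives > 25000 nM, also a limit. Compound 3 therefore stands where the whole set stands: the limit of > 25000 nM in this assay, at which 3 of the 3 values shown sit, and no member separates from the others on the numbers shown.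

Compound 4 `Cc1cc(NC(=O)Nc2ccccc2F)c2ccccc2n1` is not yet measured. It differs from compound 3 in one place: hydrogen in place of fluoro on an aromatic carbon. Among the measured compounds shown here, no measured pair in the set differs in only one place, so no step size can be read from the data. For the measured compounds named here, the expectation for compound 4 is that hydrogen in place of fluoro does not move it beyond the scatter of this assay, because every value so far sits at the limit of > 25000 nM in this assay, at which 3 of the 3 values shown sit. The expected step is a step that the limit leaves unreadable from compound 3 to compound 4, which is to say none beyond the scatter. Compound 4 is estimated at 30000 nM in this assay, with a range from 15000 nM to 60000 nM, and most likely reported again only as a limit.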

Compound 4, half-maximal effective concentration: > 25000 nM
Compound 4: no number, only a limit (the forecaster's own chance of this, stated with the estimate: 90%); the middle value is on the limit's open side.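

Compound 3 and compound 4 are both reported only as limits, so no step can be read between them, and the series stays where it stood: the limit of > 25000 nM in this assay, at which 4 of the 4 values shown sit.

Still open, from the compounds shown here alone, is the concentration at which any of the four compounds reaches a half-maximal effect in this assay, and whether hydrogen in place of fluoro on an aromatic carbon shifts it at all.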